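The compounds below may be only part of what the source reports. "The series", "measured", "known", "first", "only" and "open" are said of these compounds alone.

The series rests on a shared core that carries a nitrile and a hydrazone linker; what changes is the group attached to the linker nitrogen. Compound 1 `Cc1ccc(Br)cc1S(=O)(=O)N(C)/N=C/c1cnn2ccc(C#N)cc12` pairs a methyl on that nitrogen with an arylsulfonyl group, and in an assay on isolated protein for inhibition of phosphatidylinositol 4,5-bisphosphate 3-kinase catalytic subunit beta isoform (Homo sapiens), read by 33P incorporation, with a stated time of 60 min (on this read-out lower numbers stand for stronger inhibition and higher numbers for weaker inhibition), compound 1 gives 620 nM. Compound 2 `Cc1ccc([N+](=O)[O-])cc1S(=O)(=O)N(Cc1ccccc1)/N=C/c1cnn2ccc(C#N)cc12` carries a benzyl in place of the methyl and a nitro-bearing arylsulfonyl group. In this assay compound 2 reaches only the assay limit, > 1000 nM, so no number is available for it (the limit of > 1000 nM in this assay, at which 1 of the 3 values shown sits). Compound 3 `CN(/N=C/c1cnn2ccc(C#N)cc12)C(=O)c1cccc([N+](=O)[O-])c1` replaces the sulfonyl by a carbonyl and keeps the nitro group, and in this assay compound 3 gives 67 nM, the lowest of the two numbers recorded; the number for compound 1 sits higher by a gap beyond the scatter.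

Compound 4 `Cc1ccc([N+](=O)[O-])cc1C(=O)N(C)/N=C/c1cnn2ccc(C#N)cc12` differs from compound 3 in one place: methyl in place of hydrogen on an aromatic carbon, a methyl in place of hydrogen on an aromatic carbon, ortho to a large group and para to a nitro group. Among the compounds with values here, no measured pair isolates such a change within this set, so the size of the step is open. The step from compound 3 to compound 4 in this assay is expected to be modest and to run toward a higher number, a 2.2-fold higher number from compound 3 to compound 4 (0.35 log units; beyond the scatter). Compound 4 is therefore estimated at 150 nM, within a range from 50 nM to 500 nM.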

Compound 4, half-maximal inhibitory concentration: 68 nM
For compound 4 the middle estimate is 2.2-fold (0.34 log units) above the measured one; the range from low to high includes it.
By their numbers in this assay, from the lowest: compounds 3 and 4 (each within the scatter of the next); then compound 1. At a limit, above all of these: compound 2.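

In this assay, a methyl in place of hydrogen on an aromatic carbon, ortho to a large group and para to a nitro group, gives a 1.0-fold higher number from compound 3 to compound 4 (0.01 log units; within the scatter), so at this position the added methyl brings no change that can be told from the scatter. Within the data shown here, this is the first step in the set between two compounds that differ in one place, and compounds 1, 2 and 3, which differ from one another in more than one place, could not isolate any single position in this way. No measurement shown here bears on the reason for this result.

From the compounds shown here alone, only methyl and hydrogen are seen at this position, so it remains open whether an ethyl, a methoxy group, a chlorine or an amine placed there would also leave the number unchanged. Going by these compounds, it is also open whether the methyl would have the same small effect with an arylsulfonyl group in place of the carbonyl, or with an amine in place of the nitro group.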